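Two Values and One Untested Stereocentre

This account rests on a few compounds, and the source may have more. Where it says the series, first, only, none or still open, it means among the compounds named here.

Measured in a functional assay on the whole organism with Mus musculus as the target; a higher number here means that more compound is needed for the effect, a lower number that less compound is needed:
- compound 1 `O=C1CC[C@@H](NC(=O)OCc2ccccc2)C(=O)N1`: 46.9 mg/kg
- compound 2 `CN1C(=O)C[C@@H](NC(=O)OCc2ccccc2)C1=O`: 82.5 mg/kg

In this assay, compound 2 gives 82.5 mg/kg, which lies within the usual scatter of compound 1 at 46.9 mg/kg, so these two values do not separate the pair. The next compound to be tested is compound 3 `CN1C(=O)C[C@H](NC(=O)OCc2ccccc2)C1=O`. The structural change from compound 2 is this: the two compounds have the same atoms and bonds and differ only in configuration as drawn: 1 of 1 stereo elements differ; a stereocentre at a saturated ring carbon is drawn R in compound 2 and S in compound 3. For the measured compounds named here, no measured pair shows what a change of this kind does in this assay, so the data give neither its size nor its direction. With no evidence for a shift either way, no step beyond the scatter is expected, and the estimate stays anchored on compound 2 at 82.5 mg/kg. The expected step is a 1.0-fold lower number from compound 2 to compound 3 (0.01 log units; within the scatter). Compound 3 is estimated at 80 mg/kg, with the expected range running from 35 mg/kg to 175 mg/kg.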

Compound 3, dose for half-maximal effect: 113 mg/kg
For compound 3 the middle estimate is 1.4-fold (0.15 log units) below the measured one; low and high end bracket the measured number.
By their numbers in this assay, from the lowest: compounds 1, 2 and 3 (each within the scatter of the next, the first and the last beyond it).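

For the compounds shown here, this pair gives the first measured reading of what changing the drawn configuration at the saturated ring carbon does in this assay, namely a 1.4-fold higher number from compound 2 to compound 3 (0.14 log units; within the scatter). The step stays within the usual scatter, so this assay does not separate the R and S forms at this position, and neither configuration can be called the better one. Any gap between the two values goes with a single structural difference: the fact that compounds 2 and 3 differ only in the configuration as drawn.

The compounds shown leave open whether the same change of configuration on the core of compound 1 would give a step of similar size. They also leave open how the assay responds when the benzyl group of the carbamate is replaced by another group, such as an amine or a longer chain.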